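Fluoro on the Phenyl Ring: A Step From Compound 2

A few compounds are considered here, and "the series" means these few. Any claim that something is new, unique, unknown or untested is made for them only; others in the source may bear on it.

Measured so far:
- compound 1, `C/C(=N\NC(N)=S)c1sc(-c2ccccc2)nc1C`: in a toxicity assay on HCT-116 cells (Homo sapiens) for cytotoxicity, read by MTT assay (on this read-out lower numbers stand for stronger inhibition of growth and higher numbers for weaker inhibition of growth), compound 1 gives 47.3 ug/mL
- compound 2, `C/C(=N\Nc1nc(-c2ccccc2)cs1)c1sc(C)nc1C`: in this assay compound 2 gives only a limit, > 100 ug/mL

Of the compounds shown here, two have been tested, and they differ in more than one place, so no single step between them can be read. Compound 2 stands at the limit of this assay: its value is not a number but the boundary of the assay, (the limit of > 100 ug/mL in this assay, at which 1 of the 2 values shown sits), so only a range is known for it, and no order against compound 1 can be stated beyond what the two values show.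

Compound 3, `C/C(=N\Nc1nc(-c2ccc(F)cc2)cs1)c1sc(C)nc1C`, is the next compound. The change from compound 2 is fluoro in place of hydrogen on an aromatic carbon, the fluoro entering on the six-membered aromatic ring of carbon only, para to a large group.

Within the data shown here, no measured step gives a bearing on this change. It is expected to be a small step, none beyond the scatter, in this assay: compound 3 is estimated at 110 ug/mL, in the range 40 ug/mL to 300 ug/mL, which means an expected step that the limit leaves unreadable from compound 2 to compound 3.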

Compound 3, concentration for 50% growth inhibition: > 100 ug/mL
Compound 3: only a limit was reported (the forecaster's own chance of this, stated with the estimate: 65%); the middle value does not contradict the limit.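

Compound 3 also gives only a limit in this assay, > 100 ug/mL, as compound 2 does, so no step from compound 2 to compound 3 can be read: the limit of > 100 ug/mL in this assay, at which 2 of the 3 values shown sit.

The compounds shown leave open whether fluoro in place of hydrogen on an aromatic carbon changes growth inhibition at all in this assay.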